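Thiophene for pyridine on two tetrazole cores

A few compounds are considered here, and "the series" means these few. Any claim that something is new, unique, unknown or untested is made for them only; others in the source may bear on it.

Compound 1 `CCCCCCCCc1ccc(OCC(=O)Cn2nnc(-c3ccccn3)n2)cc1`: 18 nM in an assay on microsomes from brain for inhibition of Fatty-acid amide hydrolase 1 (Rattus norvegicus), read by fluorescence and HPLC, with a stated time of 60 min; a higher number here means a weaker inhibitor, a lower number a stronger inhibitor
Compound 2 `CCCCCCCCc1ccc(OCC(=O)Cn2nnc(-c3cccs3)n2)cc1`: 32 nM in this assay
Compound 3 `CCCCCCCCc1ccc(OCC(=O)Cn2nnnc2-c2ccccn2)cc1`: 880 nM in this assay

Compounds 1 and 2 share a core and differ only by thiophen-2-yl in place of pyridin-2-yl on an aromatic carbon; this gave a 1.8-fold higher number from compound 1 to compound 2 (0.25 log units; within the scatter). Compound 3 is built from the same atoms as compound 1 joined differently; the difference between the two cores is not broken down here. Compound 3 stands well weaker than both compound 1 and compound 2 in this assay.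

Compound 4 `CCCCCCCCc1ccc(OCC(=O)Cn2nnnc2-c2cccs2)cc1` has not been measured. It differs from compound 3 by thiophen-2-yl in place of pyridin-2-yl on an aromatic carbon, the same kind of change as from compound 1 to compound 2, though here the changed carbon sits next to the ring atom that bears a large group, whereas in compound 1 it lay two ring bonds from that atom. Resting on the small step of a 1.8-fold higher number from compound 1 to compound 2 (0.25 log units; within the scatter), compound 4 is expected to lie close to compound 3, with a 1.4-fold higher number from compound 3 to compound 4 (0.13 log units; within the scatter). The estimated value for compound 4 in this assay is 1200 nM, between 450 nM and 3500 nM.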

Compound 4, half-maximal inhibitory concentration: 55 nM
For compound 4 the middle estimate is 22-fold (1.34 log units) above the measured one; measured number below the stated range.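

In this assay thiophen-2-yl in place of pyridin-2-yl gave a 1.8-fold higher number from compound 1 to compound 2 (0.25 log units; within the scatter) on the first core and a 16-fold lower number from compound 3 to compound 4 (1.20 log units; beyond the scatter) on the second. Within the data shown here, with only one pair on each core, this does not show why the cores differ, or whether any other group in place of pyridin-2-yl would behave the same way. It does show that the size of this step on one core cannot be carried over to the other: the same change on two cores in this assay, a 1.8-fold higher number (0.25 log units; within the scatter) from compound 1 to compound 2 and a 16-fold lower number (1.20 log units; beyond the scatter) from compound 3 to compound 4, 28-fold (1.45 log units) apart, beyond the scatter of two such steps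

The compounds shown leave open whether phenyl would follow thiophen-2-yl or pyridin-2-yl on either core. They also leave open whether the gap between the two steps would persist with a shorter chain in place of the octyl chain.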